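Removing a Nitro Group on Two Different Cores

The source may report more compounds than this note shows. Statements on the series, on what has been measured and on what is new or still open speak of the compounds shown alone.

Compound 3 `COc1ccc2c(c1)CCC/C2=N\NCc1nc2cc([N+](=O)[O-])ccc2[nH]1` and compound 2 `COc1ccc2c(c1)CCC/C2=N\NCc1nc2ccccc2[nH]1` share one core and differ in a single place, (hydrogen in place of nitro on an aromatic carbon). In a functional assay on HepG2 cells (Homo sapiens) for cytotoxicity, read by MTT assay (a lower number here means a stronger inhibitor, a higher number a weaker inhibitor), compound 3 gives 96000 nM, and compound 2 gives 80000 nM; the step of a 1.2-fold lower number from compound 3 to compound 2 (0.08 log units; within the scatter). Compound 1 `NS(=O)(=O)c1nnc(NCc2nc3cc([N+](=O)[O-])ccc3[nH]2)s1` is built on another core, and the difference between the two cores is not broken down here. In this assay compound 1 gives 184000 nM, which lies beyond the scatter from compound 2 but within it from compound 3. Compound 4 `NS(=O)(=O)c1nnc(NCc2nc3ccccc3[nH]2)s1` has not yet been measured; it arises from compound 1 by the same change that turns compound 3 into compound 2, (hydrogen in place of nitro on an aromatic carbon). Because the step of a 1.2-fold lower number from compound 3 to compound 2 (0.08 log units; within the scatter) stayed within the scatter, the step expected from compound 1 to compound 4 in this assay is also small, a 1.2-fold lower number from compound 1 to compound 4 (0.09 log units; within the scatter). On that basis compound 4 is estimated to give about 150000 nM, with the number expected to fall between 70000 nM and 320000 nM.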

Compound 4, half-maximal inhibitory concentration: 162000 nM
The estimate for compound 4 lay 1.1-fold (0.03 log units) below the measured number, and the stated range covers the measured number.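

In this assay, putting hydrogen in place of nitro on the core of compound 1 gives a 1.1-fold lower number from compound 1 to compound 4 (0.06 log units; within the scatter). Set beside the same change on the other core, the two steps cannot be told apart: the same change on two cores in this assay, a 1.2-fold lower number (0.08 log units; within the scatter) from compound 3 to compound 2 and a 1.1-fold lower number (0.06 log units; within the scatter) from compound 1 to compound 4, 1.1-fold (0.02 log units) apart, within the scatter of two such steps

This shows that, in this small series, the change carried from one core to the other without a detectable difference, and that neither step could be separated from the scatter. It does not show that the nitro group is without consequence in general, since the result rests on two pairs of compounds in a single assay and says nothing about any other core or any other read-out.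

The compounds shown leave open what a different group on that aromatic carbon, such as an amine or a carboxylic acid, would do in this assay. They also leave open which parts of the two cores account for any difference between them.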